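The source may hold more compounds than are shown below. What is called first, only, known or untested is meant among the compounds shown, and "the series" means these compounds.

In an ADME assay on Vero cells (Chlorocebus sabaeus) for cytotoxicity, read by MTT assay, with a stated time of 96 h (a lower number here means that less compound is tolerated, a higher number that more compound is tolerated), three compounds with a shared core differ only in the group on a double-bonded nitrogen. Compound 1 `C/C(=N\O)c1ccc2[nH]c(-c3ccccc3)nc2c1` reads > 100000 nM, which is a limit of the assay and not a number. Compound 2 `C/C(=N\NC(N)=O)c1ccc2[nH]c(-c3ccccc3)nc2c1` reads > 100000 nM, again a limit. Compound 3 `C/C(=N\NC(N)=S)c1ccc2[nH]c(-c3ccccc3)nc2c1` reads > 100000 nM, also a limit. Compound 3 therefore stands at the limit of > 100000 nM in this assay, at which 3 of the 3 values shown sit.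

The measured changes give no size to build on: a step that the two limits leave unreadable from compound 1 to compound 2, a step that the two limits leave unreadable from compound 1 to compound 3 and a step that the two limits leave unreadable from compound 2 to compound 3. None of them touches the aromatic nitrogen that changes next.

Compound 4 `C/C(=N\NC(N)=S)c1ccc2c(c1)nc(-c1ccccc1)n2C1CCCCC1` carries cyclohexyl in place of hydrogen on that aromatic nitrogen: cyclohexyl in place of hydrogen on an aromatic nitrogen. Within the data shown here, with no measured step to guide it, this expectation is a cautious one: the reading may stay at the limit, or it may fall modestly, towards less compound being tolerated. The expected change is an at least 2.0-fold lower number from compound 3 to compound 4 (0.30 log units; that floor lies within the scatter). For compound 4, the estimated value is 50000 nM, with an expected range from 12000 nM to 100000 nM.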

Compound 4, half-maximal cytotoxic concentration: 20000 nM
Estimate against measurement, compound 4: 2.5-fold (0.40 log units) above, within the range that was stated.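

In this assay, among these compounds, the aromatic nitrogen is the first place where a change brings a reading away from the limit, with an at least 5.0-fold lower number from compound 3 to compound 4 (0.69 log units; beyond the scatter) on adding cyclohexyl, a step beyond the usual scatter. The earlier steps on the double-bonded nitrogen cannot be read, and compound 4 is the only compound shown with a real number, while the others stay at the limit: the limit of > 100000 nM in this assay, at which 3 of the 4 values shown sit. Compound 3 gives > 100000 nM, which is a limit of the assay and not a number, so the true step could be larger.

On these data alone, it remains open whether a smaller group on this nitrogen, such as methyl, or an open carbon chain would lower the number as cyclohexyl does. Also open, as far as these compounds go, is whether cyclohexyl would act the same way with the hydroxy group of compound 1 or the ureido group of compound 2 on the double-bonded nitrogen.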